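Amide-head variations on a shared core: hydroxy on the anilide

The compounds below may be only part of what the source reports. "The series", "measured", "known", "first", "only" and "open" are said of these compounds alone.

Measured so far in a functional assay on LNCaP cells (Homo sapiens) for inhibition, read by MTT assay; on this read-out lower numbers stand for stronger inhibition of growth and higher numbers for weaker inhibition of growth:
Compound 1, `CC1=C(/C=C/C(C)=C/C=C/C(C)=C\C(=O)NCc2ccc(O)cc2)C(C)(C)CCC1n1ccnc1`: 1690 nM
Compound 2, `CC1=C(/C=C/C(C)=C/C=C/C(C)=C\C(=O)Nc2ccccc2)C(C)(C)CCC1n1ccnc1`: 2690 nM

Compound 2 carries the higher of the two numbers shown, but the step of a 1.6-fold higher number from compound 1 to compound 2 (0.20 log units; within the scatter) is within the scatter, so no order between compound 1 and compound 2 is claimed. Compound 3, `CC1=C(/C=C/C(C)=C/C=C/C(C)=C\C(=O)Nc2ccccc2O)C(C)(C)CCC1n1ccnc1`, differs from compound 2 by hydroxy in place of hydrogen on an aromatic carbon. Among the compounds with values here, the only measured step, a 1.6-fold higher number from compound 1 to compound 2 (0.20 log units; within the scatter), reworks the same amide-type nitrogen substituent, but it exchanges 4-hydroxybenzyl for phenyl, so it swaps a hydroxy together with a benzylic carbon; no measured step introduces a hydroxy alone on an aromatic carbon. Since that one step stayed within the scatter, the expectation for compound 3 is a step of about a 1.2-fold lower number from compound 2 to compound 3 (0.09 log units; within the scatter), that is, nothing beyond the scatter in this assay. Compound 3 is therefore estimated at 2200 nM, with a range from 900 nM to 5500 nM.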

Compound 3, concentration for 50% growth inhibition: 3230 nM
Compound 3: the middle estimate sits 1.5-fold (0.17 log units) below what was measured; the range from low to high includes it.
By their numbers in this assay, from the lowest: compounds 1, 2 and 3 (each within the scatter of the next).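

In this assay, a hydroxy on an aromatic carbon, ortho to a large group, can now be read on its own, and it gives a 1.2-fold higher number from compound 2 to compound 3 (0.08 log units; within the scatter), so this change at this position does not separate the two compounds. The pair that differs in the whole amide-nitrogen substituent, with 2-hydroxyphenyl in place of 4-hydroxybenzyl, shows a 1.9-fold higher number from compound 1 to compound 3 (0.28 log units; within the scatter), so none of the three substituents shown stands apart from the others. No supporting data accompany this result, so nothing can be said about the reason for it.

Going by these compounds, it remains open whether an amine or a methoxy at this same place, or a 4-hydroxyphenyl group, would step beyond the scatter. On these data alone, a 2-phenylethyl group or a carboxylic acid on the amide head is equally open.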